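Propyl ether to free hydroxymethyl on the dibromocatechol

A few compounds are considered here, and "the series" means these few. Any claim that something is new, unique, unknown or untested is made for them only; others in the source may bear on it.

For the measured compounds named here, compound 2 `CCCOCc1cc(O)c(O)c(Br)c1Br` holds the lowest of the two numbers so far in a functional assay on DLD-1 cells (Homo sapiens) for cytotoxicity, read by MTT assay, with a stated time of 96 h; a higher number here means a weaker inhibitor, a lower number a stronger inhibitor: compound 2 gives 12400 nM. Its nearest neighbour on the numbers is compound 1 `OCc1cc(O)c(O)c(Br)c1`, which in this assay gives 51500 nM, a gap beyond the scatter; the two differ in more than one place, so their values are only read side by side. Compound 3 `OCc1cc(O)c(O)c(Br)c1Br` is not yet measured. The change from compound 2 to compound 3 is hydrogen in place of propyl on an oxygen on a saturated carbon. Going by the values given here, no measured pair isolates this change. Compound 1 carries the same hydroxymethyl group and stands on the weaker side, so a step towards weaker inhibition is expected, of modest size. For compound 3 the expectation in this assay is 30000 nM, within 12000 nM to 80000 nM. The expected step is a 2.4-fold higher number from compound 2 to compound 3 (0.38 log units; beyond the scatter).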

Compound 3, half-maximal inhibitory concentration: 18300 nM
The estimate for compound 3 lay 1.6-fold (0.21 log units) above the measured number; the measured number falls inside the stated range.
By their numbers in this assay, from the lowest: compounds 2 and 3 (each within the scatter of the next); then compound 1.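

Taking the propyl off the oxygen leaves the number in this assay essentially unmoved, with a 1.5-fold higher number from compound 2 to compound 3 (0.17 log units; within the scatter), so this pair sets no order between propoxymethyl and hydroxymethyl on the dibrominated core. For the compounds shown here, the extra bromo, by contrast, gives the one step here that clears the scatter, with a 2.8-fold lower number from compound 1 to compound 3 (0.45 log units; beyond the scatter), and this single-place comparison separates that change from the ether change that compound 1 and compound 2 could only show together. Nothing available explains either step.

Still open, on these data alone, is whether a longer chain, a benzyl group or an aminoethyl group on the same oxygen would also leave the number within the scatter of compound 3. As far as these compounds go, each change also rests on a single pair, so whether the bromo step would carry over to the propyl ether remains unknown.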